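Taking a Methoxy Off Compound 2

The source may hold more compounds than are shown below. What is called first, only, known or untested is meant among the compounds shown, and "the series" means these compounds.

Measured so far in a functional assay on HeLa cells (Homo sapiens) for antiproliferative activity, read by MTT assay, with a stated time of 48 h; a higher number here means a weaker inhibitor, a lower number a stronger inhibitor:
- compound 1 `COc1ccc2c(/C=C/C(=O)c3cc(N)c(OC)c(OC)c3)c[nH]c2c1`: 155 nM
- compound 2 `COc1ccc2c(/C=C/C(=O)c3cc(OC)c(OC)c([N+](=O)[O-])c3)c[nH]c2c1`: 850 nM

Of these two compounds, compound 2 has the higher number, 850 nM, and is therefore the weaker inhibitor. Among the measured compounds shown here, its only neighbour is compound 1, at 155 nM. The next compound, compound 3 `COc1cc(C(=O)/C=C/c2c[nH]c3ccccc23)cc([N+](=O)[O-])c1OC`, keeps the nitro group of compound 2 but carries hydrogen in place of methoxy on an aromatic carbon.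

For the measured compounds named here, no measured pair tests this change directly. Going by the values given here, the only measured step is a 5.5-fold higher number from compound 1 to compound 2 (0.74 log units; beyond the scatter), and it concerns nitro in place of amino at a different place on the molecule. It therefore says nothing firm about direction here, and serves only as a guide to how far one small change can move a number in this assay. A step of similar or smaller size seems reasonable, with a slight lean towards weaker inhibition, though the opposite direction cannot be excluded. The estimate corresponds to an expected 1.8-fold higher number from compound 2 to compound 3 (0.25 log units; within the scatter). For compound 3 the expected value is 1500 nM, with an estimated range of 400 nM to 6000 nM.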

Compound 3, half-maximal inhibitory concentration: 1350 nM
Estimate against measurement, compound 3: 1.1-fold (0.05 log units) above, within the range that was stated.
By their numbers in this assay, from the lowest: compound 1; then compounds 2 and 3 (each within the scatter of the next).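

In this assay, among the compounds shown here, putting hydrogen in place of methoxy on an aromatic carbon of the six-membered aromatic ring of carbon only, part of a fused system of two rings, gives a 1.6-fold higher number from compound 2 to compound 3 (0.20 log units; within the scatter), the first reading at this position, since the earlier step concerned nitro in place of amino at a different place on the molecule. With the nitro group kept, compound 2 and compound 3 cannot be told apart in this assay, so the methoxy at this position is not required for the level of activity seen with compound 2, and this single pair gives no sign that the position is sensitive to this particular change. Nothing available offers an explanation for this result.

Going by these compounds, this pair covers only the compounds carrying the nitro group, so it remains open whether hydrogen in place of methoxy would read the same alongside the amino group of compound 1, the stronger inhibitor of that earlier pair. Also open, on these data alone, is how other groups at this position would read, such as a hydroxyl, a fluorine or a longer ethoxy chain, since methoxy and hydrogen are only two of the possibilities.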